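The compounds below may be only part of what the source reports. "The series", "measured", "known", "first", "only" and "open" are said of these compounds alone.

Measured so far:
- compound 1 `Cc1cc(NCc2cccnc2)n2nc(C)c(-c3ccccc3)c2n1` gives 110000 nM
- compound 2 `Cc1cc(NCc2ccccn2)n2ncc(-c3ccc(C(F)(F)F)cc3)c2n1` gives < 5000 nM

Of the compounds shown here, two have been measured in a physicochemical assay for solubility, read by HPLC, using the shake flask method, measured as kinetic solubility, with a stated time of 2 h, at pH 7.4; on this read-out higher numbers stand for higher solubility and lower numbers for lower solubility. Among the compounds with values here, compound 1 is the only one with a proper number; in this assay compound 1 gives 110000 nM. Compound 2 sits at the limit of the assay rather than at a number, and in this assay compound 2 gives < 5000 nM, which is to be read as a limit (the limit of < 5000 nM in this assay, at which 1 of the 2 values shown sits). Within the data shown here, since compound 1 and compound 2 differ in more than one place, no single step can be drawn between them, and no measured step of any kind is available to lean on.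

The compound not yet measured is compound 3 `CCN1CCCC1CNc1cc(C)nc2c(-c3ccccc3)c(C)nn12`. It differs from compound 1 in one place (1-ethylpyrrolidin-2-yl in place of pyridin-3-yl on a saturated chain carbon bound to a nitrogen on an aromatic ring). Among the measured compounds shown here, with no measured step to anchor the expectation, the size of the change in this assay can only be guessed. For compound 3 a step of a 2.3-fold higher number from compound 1 to compound 3 (0.36 log units; beyond the scatter) towards higher solubility is expected. Compound 3 is thus estimated at 250000 nM, with a range from 90000 nM to 600000 nM.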

Compound 3, solubility: 172000 nM
For compound 3 the middle estimate is 1.5-fold (0.16 log units) above the measured one, and the stated range covers the measured number.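

In this assay, 1-ethylpyrrolidin-2-yl in place of pyridin-3-yl on a saturated chain carbon bound to a nitrogen on an aromatic ring gives a 1.6-fold higher number from compound 1 to compound 3 (0.19 log units; within the scatter). Within the data shown here, this is the first measured step at this position, and it leaves the two compounds indistinguishable on this read-out. A six-membered aromatic ring and a five-membered non-aromatic ring, each with 1 hetero atom, can therefore be exchanged here on the core of compound 1 without a difference that stands clear of repeat measurements, although no measurement shown explains why this exchange gives this result.

The compounds shown leave open how far this holds at the same place: a carboxylic acid, a morpholine ring or a longer chain might stay equally close to compound 1 or move well away from it. Also open, going by these compounds, is whether the same exchange would give a similar step on a different core, as this single pair sets no general rule.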